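A few compounds are considered here, and "the series" means these few. Any claim that something is new, unique, unknown or untested is made for them only; others in the source may bear on it.

Measured so far in a functional assay on SK-MEL-2 cells (Homo sapiens) for inhibition, read by sulforhodamine B assay, with a stated time of 48 h; a higher number here means a weaker inhibitor of growth, a lower number a stronger inhibitor of growth:
compound 1 `COc1cc(-c2nn(-c3cccc(NC(=O)Nc4ccc(Cl)c(Cl)c4)c3)cc2-c2ccncc2)ccc1Cl`: 2350 nM
compound 2 `O=C(Nc1cccc(-n2cc(-c3ccncc3)c(-c3ccc(Cl)c(O)c3)n2)c1)Nc1ccc(Cl)c(Cl)c1`: 2640 nM
compound 3 `COc1cc(-c2nn(-c3cccc(NC(=O)c4ccc(Cl)c(C(F)(F)F)c4)c3)cc2-c2ccncc2)ccc1Cl`: 19700 nM

Compound 2 stands second highest of the three numbers: its value and that of compound 1 lie within the scatter of each other, while compound 3 gives a number beyond the scatter above both. Compound 4 `O=C(Nc1cccc(-n2cc(-c3ccncc3)c(-c3ccc(Cl)c(O)c3)n2)c1)Nc1ccc(Cl)c(C(F)(F)F)c1` is not yet measured and differs from compound 2 in one place: trifluoromethyl in place of chloro on an aromatic carbon. For the measured compounds named here, no measured step isolates this change. The closest is an 8.4-fold higher number from compound 1 to compound 3 (0.92 log units; beyond the scatter), but that step joins the same chloro-to-trifluoromethyl swap with loss of the amino group on the carbonyl carbon, so it only sets an outer bound. The step of a 1.1-fold higher number from compound 1 to compound 2 (0.05 log units; within the scatter) shows that the hydrogen-for-methyl change on the oxygen, which compound 2 carries, is neutral, so compound 2 is a sound starting point. In this assay a step of at most modest size is expected, more likely toward a higher number than a lower one, and possibly none beyond the scatter. Compound 4 is therefore estimated at 4000 nM, with a range from 1500 nM to 12000 nM. The expected step is a 1.5-fold higher number from compound 2 to compound 4 (0.18 log units; within the scatter).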

Compound 4, concentration for total growth inhibition: 1730 nM
Compound 4: the middle estimate sits 2.3-fold (0.36 log units) above what was measured, and the stated range covers the measured number.
By their numbers in this assay, from the lowest: compounds 4, 1 and 2 (each within the scatter of the next); then compound 3.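

In this assay, trifluoromethyl in place of chloro on this aromatic carbon, ortho to a chloro group, gives a 1.5-fold lower number from compound 2 to compound 4 (0.18 log units; within the scatter), so within the urea pair this position takes four heavy atoms in place of one without a change beyond the scatter. The swap alone therefore does not account for an 8.4-fold higher number from compound 1 to compound 3 (0.92 log units; beyond the scatter), which points to the loss of the amino group on the carbonyl carbon as the part of that step still to be isolated, though compound 1 and compound 3 carry a methyl on the oxygen that compound 2 and compound 4 lack. No available evidence explains the size of this step.

Going by these compounds, whether the position also accepts a methyl, a nitrile or a morpholine remains open. Also open, on these data alone, is whether the same swap stays within the scatter when the oxygen carries a methyl.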